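The compounds below may be only part of what the source reports. "The series", "measured", "known", "first", "only" and "open" are said of these compounds alone.

Compounds measured in a functional assay on the whole organism for inhibition, with Rattus norvegicus as the target, read by paw edema; a lower number here means that less compound is needed, a higher number that more compound is needed for the effect:
compound 1, `O=C(O)c1cc(-c2cncs2)ccc1O`, gives > 200 mg/kg, a limit of the assay rather than a number.
compound 2, `O=C(O)c1cc(-c2cccs2)ccc1O`, gives 60 mg/kg.
compound 3, `O=C(O)c1cc(-c2cscn2)ccc1O`, gives 95 mg/kg.

The three compounds share one core and differ only in the five-membered ring attached to it. Of the two numbers on record, compound 2 holds the lowest; the step of a 1.6-fold higher number from compound 2 to compound 3 (0.20 log units; within the scatter) is small. The other change, an at least 3.3-fold lower number from compound 1 to compound 2 (0.52 log units; beyond the scatter), is larger and rests on (the limit of > 200 mg/kg in this assay, at which 1 of the 3 values shown sits).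

Compound 4, `O=C(O)c1cc(-c2csnn2)ccc1O`, is not yet measured in this assay. It differs from compound 2 as follows: 1,2,3-thiadiazol-4-yl in place of thiophen-2-yl on an aromatic carbon.

Among the measured compounds shown here, two measured steps bear on this change. The step of a 1.6-fold higher number from compound 2 to compound 3 (0.20 log units; within the scatter) shows that a ring with more hetero atoms can be tolerated within the scatter, while an at least 3.3-fold lower number from compound 1 to compound 2 (0.52 log units; beyond the scatter) shows that another such ring costs markedly. For the measured compounds named here, no measured step covers the 1,2,3-thiadiazol-4-yl itself, so the expectation is a modest rise in dose, near the edge of the scatter, expressed as a 1.8-fold higher number from compound 2 to compound 4 (0.26 log units; within the scatter). Compound 4 is therefore estimated at about 110 mg/kg, with a range from 50 mg/kg to 250 mg/kg.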

Compound 4, dose for half-maximal effect: > 200 mg/kg
Compound 4 ended at the assay's limit; the forecaster's own chance of this, stated with the estimate: 25%; middle value at least 1.8-fold (0.25 log units) away from the limit.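

In this assay compound 4 gives > 200 mg/kg as a limit of the assay and not a number. On this aromatic carbon, meta to a carboxy group and para to a hydroxy group, the 1,2,3-thiadiazol-4-yl ring therefore costs more than the scatter, with an at least 3.3-fold higher number from compound 2 to compound 4 (0.52 log units; beyond the scatter) and with an at least 2.1-fold higher number from compound 3 to compound 4 (0.32 log units; beyond the scatter) as well, so the tolerance seen for the 1,3-thiazol-4-yl ring does not extend to every ring with more hetero atoms. The count of hetero atoms alone does not sort the series, as compound 1 also stays at the limit while compound 3 gives a readable value, and the step between compound 1 and compound 4 cannot be read: the limit of > 200 mg/kg in this assay, at which 2 of the 4 values shown sit.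

The compounds shown leave open how far past the limit compound 1 and compound 4 lie, so these two rings cannot be ranked against each other. They also leave open whether a furan-2-yl or phenyl ring at this place would stay as close to compound 2 as compound 3 does, or whether a methyl group on the 1,2,3-thiadiazol-4-yl ring would bring the dose back into readable range.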